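Chloro for hydrogen on two related cores

The compounds below may be only part of what the source reports. "The series", "measured", "known", "first", "only" and "open" are said of these compounds alone.

Compound 1 `ClCc1cccc(Cn2cnc3c(Cl)ncnc32)c1` and compound 3 `ClCc1ccccc1Cn1cnc2ncnc(Cl)c21` have the same atoms joined differently; the difference between the two cores is not broken down here. In a functional assay on OVCAR-8 cells (Homo sapiens) for cytotoxicity, read by sulforhodamine B assay, with a stated time of 48 h (a lower number here means that less compound is tolerated, a higher number that more compound is tolerated), compound 1 gives 79400 nM and compound 3 gives 58900 nM. Compound 2 `ClCc1cccc(Cn2cnc3c(Cl)nc(Cl)nc32)c1` carries one change relative to compound 1, (chloro in place of hydrogen on an aromatic carbon), and in this assay compound 2 gives 67600 nM, a step of a 1.2-fold lower number from compound 1 to compound 2 (0.07 log units; within the scatter). Compound 4 `ClCc1ccccc1Cn1cnc2nc(Cl)nc(Cl)c21`, not yet measured, carries the same change on the core of compound 3: chloro in place of hydrogen on an aromatic carbon. This change occurs twice among these compounds, once measured. Because the measured instance gave a 1.2-fold lower number from compound 1 to compound 2 (0.07 log units; within the scatter) within the scatter, the expected step is a 1.2-fold lower number from compound 3 to compound 4 (0.07 log units; within the scatter). For compound 4 in this assay the estimate is 50000 nM, expected to fall from 30000 nM to 90000 nM.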

Compound 4, concentration lethal to 50% of the cells: 75900 nM
Estimate against measurement, compound 4: 1.5-fold (0.18 log units) below; the range from low to high includes it.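

In this assay, chloro in place of hydrogen on the aromatic carbon between two ring nitrogen atoms gives a 1.3-fold higher number from compound 3 to compound 4 (0.11 log units; within the scatter), so on the core of compound 3 the change does not stand out from the scatter. Set beside the earlier step, the two cores show no difference in their response to this change: the same change on two cores in this assay, a 1.2-fold lower number (0.07 log units; within the scatter) from compound 1 to compound 2 and a 1.3-fold higher number (0.11 log units; within the scatter) from compound 3 to compound 4, 1.5-fold (0.18 log units) apart, within the scatter of two such steps. Among these compounds, this shows only that the change stays within the scatter on both cores; it fixes no size or direction for the change and says nothing about other cores or assays.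

Still open, from the compounds shown here alone, is whether another group at this place, such as an amine or a methoxy group, would move the number beyond the scatter. Going by these compounds, all four compounds carry a chloromethyl group, so the effect of replacing it with a plain methyl also remains open.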